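This account rests on a few compounds, and the source may have more. Where it says the series, first, only, none or still open, it means among the compounds named here.

- compound 1 `OCCCCCC(O)c1ccc(-c2ccc(O)cc2)cc1`: 15000 nM
- compound 2 `OCCCCCC(O)c1ccc(-c2ccc(OC(F)(F)F)cc2)cc1`: 14000 nM

In a functional assay on J774 cells (Mus musculus) for cytotoxicity, read by resazurin assay (on this read-out higher numbers stand for weaker inhibition and lower numbers for stronger inhibition), compound 2 gives 14000 nM. That value lies within the scatter of compound 1 at 15000 nM, so the two stand level and neither ranks above the other.

The next compound is compound 3 `CN(C)c1ccc(-c2ccc(C(O)CCCCCO)cc2)cc1`, with dimethylamino in place of trifluoromethoxy on an aromatic carbon, para to a large group: dimethylamino in place of trifluoromethoxy on an aromatic carbon.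

Within the data shown here, only one measured step bears on this: a 1.1-fold lower number from compound 1 to compound 2 (0.03 log units; within the scatter). It placed trifluoromethyl on the oxygen on the aromatic ring, and it stayed within the scatter. Among the measured compounds shown here, no measured compound carries dimethylamino, so this evidence is thin and the range is kept wide.

The expected change is no more than scatter, with the estimated step of a 1.1-fold lower number from compound 2 to compound 3 (0.03 log units; within the scatter). Compound 3 is estimated at 13000 nM, with an expected range of 6000 nM to 26000 nM.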

Compound 3, half-maximal inhibitory concentration: 28000 nM
Compound 3: middle estimate off by 2.2-fold (0.33 log units), on the low side; measured number above the stated range.
By their numbers in this assay, from the lowest: compounds 2, 1 and 3 (each within the scatter of the next).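

In this assay, dimethylamino on an aromatic carbon, para to a large group, stays within the scatter of trifluoromethoxy (a 2.0-fold higher number from compound 2 to compound 3 (0.30 log units; within the scatter)) and of hydroxy (a 1.9-fold higher number from compound 1 to compound 3 (0.27 log units; within the scatter)). A group joined through nitrogen therefore joins the two joined through oxygen, and the three compounds show no separation at this position. No measurement is available that would explain the size of either step.

Going by these compounds, it remains open whether a carboxylic acid, a primary amine or a nitrile at this position would give a step beyond the scatter in this assay. The compounds shown also leave open what a shorter or longer chain would do in place of the chain that all three share.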